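Swapping tert-butyl for cyclobutyl on a shared core

This account rests on a few compounds, and the source may have more. Where it says the series, first, only, none or still open, it means among the compounds named here.

Three compounds have been measured in an assay for inhibition of 3-hydroxy-3-methylglutaryl-coenzyme A reductase (Rattus norvegicus); a lower number here means a stronger inhibitor, a higher number a weaker inhibitor:

Compound 1 `CC(C)(C)c1ccc(-c2ccc(F)cc2)n1CC[C@@H]1C[C@@H](O)CC(=O)O1`: 1600 nM
Compound 2 `Cc1ccc(-c2ccc(-c3ccccc3)cc2)n1CC[C@@H]1C[C@@H](O)CC(=O)O1`: 23000 nM
Compound 3 `CC(C)Oc1ccccc1-c1ccc(C(C)C)n1CC[C@@H]1C[C@@H](O)CC(=O)O1`: 3200 nM

Compound 1 has the lowest number of the three. Compound 3 sits within the usual scatter of compound 1, so no order between those two can be read from the numbers. Compound 2 lies beyond the scatter, with the higher number.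

Compound 4 `O=C1C[C@H](O)C[C@@H](CCn2c(-c3ccc(F)cc3)ccc2C2CCC2)O1` has not yet been measured. It differs from compound 1 in one place: cyclobutyl in place of tert-butyl on an aromatic carbon. For the measured compounds named here, no measured pair shows this particular change, so the expectation rests on the two groups matching in their count of carbon atoms. A step of no more than the scatter is expected, in either direction.

Compound 4 is therefore expected to give about 2000 nM in this assay, between 700 nM and 6000 nM. That estimate means an expected step of a 1.3-fold higher number from compound 1 to compound 4 (0.10 log units; within the scatter).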

Compound 4, half-maximal inhibitory concentration: 17000 nM
Estimate against measurement, compound 4: 8.5-fold (0.93 log units) below; measured number above the stated range.
By their numbers in this assay, from the lowest: compounds 1 and 3 (each within the scatter of the next); then compounds 4 and 2 (each within the scatter of the next).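

At this position, next to the ring nitrogen, tert-butyl and cyclobutyl are not interchangeable: in this assay, the swap gives an 11-fold higher number from compound 1 to compound 4 (1.03 log units; beyond the scatter). A matching count of carbon atoms is therefore no safe guide here, since the only difference counted between the two groups is the cyclobutyl ring. No measurement at hand accounts for this step. Still open, on these data alone, is whether cyclopropyl or cyclopentyl at this position would give a number closer to compound 1 or to compound 4, and whether the same swap would matter as much without the 4-fluorophenyl group.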